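Aryloxypentyloxy phenylthioureas: cytotoxicity notes ahead of compound 4

A few compounds are considered here, and "the series" means these few. Any claim that something is new, unique, unknown or untested is made for them only; others in the source may bear on it.

Three members of the series have been run in an ADME assay on Ava5 cells (Homo sapiens) for cytotoxicity; on this read-out lower numbers stand for higher toxicity in this test and higher numbers for lower toxicity in this test. In this assay compound 2 `NC(=S)Nc1cccc(OCCCCCOc2ccc(F)cc2)c1` gives 5000 nM, the lowest of the two plain numbers in hand. Compound 3 `NC(=S)Nc1cccc(OCCCCCOc2cccc(Cc3ccccc3)c2)c1` gives 13000 nM in this assay, a gap to compound 2 that lies beyond the usual scatter. Compound 1 `CC(CCOc1ccccc1)CCOc1cccc(NC(N)=S)c1` gives > 50000 nM in this assay, a limit rather than a number, namely (the limit of > 50000 nM in this assay, at which 1 of the 3 values shown sits). Compound 4 `NC(=S)Nc1cccc(OCCCCCOc2ccc(-c3ccco3)cc2)c1` has not been measured; it differs from compound 2 as follows: furan-2-yl in place of fluoro on an aromatic carbon. Among the compounds with values here, no step between measured compounds shares this change, so any expectation rests on compound 3, whose 13000 nM comes with a larger group on the distal ring and a higher number than compound 2. The expected step is a 1.6-fold higher number from compound 2 to compound 4 (0.20 log units; within the scatter), a modest rise sitting near the edge of the scatter. Compound 4 is expected to give 8000 nM, within 2500 nM to 25000 nM.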

Compound 4, half-maximal cytotoxic concentration: 11000 nM
For compound 4 the middle estimate is 1.4-fold (0.14 log units) below the measured one, and the stated range covers the measured number.
By their numbers in this assay, from the lowest: compound 2; then compounds 4 and 3 (each within the scatter of the next). At a limit, above all of these: compound 1.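

Within the data shown here, this is the only matched pair at this position, the aromatic carbon para to a large group, and in this assay furan-2-yl in place of fluoro gives a 2.2-fold higher number from compound 2 to compound 4 (0.34 log units; beyond the scatter). The earlier compounds shown here held no such single-place step, and this one shows that a five-membered aromatic ring with five heavy atoms can replace the single fluorine here and move the read-out modestly towards lower toxicity in this test, not higher. Nothing in hand accounts for the size or direction of this step.

Still open, from the compounds shown here alone, is whether the rise follows the ring itself, its oxygen or the loss of fluoro, which a thiophen-2-yl, a methoxy group or an amine at this position would help to separate. One pair also leaves open whether the same exchange would hold on a longer chain.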